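Ureido Replaces Aminoethyl on a Shared Quinoline-Free Core

This account rests on a few compounds, and the source may have more. Where it says the series, first, only, none or still open, it means among the compounds named here.

Compound 1 `CC(O)CNc1cc(N2CCc3ccccc3C2)nc2ccccc12`: 89000 nM
Compound 2 `NCCCCNc1cc(N2CCc3ccccc3C2)nc2ccccc12`: 7400 nM

In an ADME assay on HEp-2 cells (Homo sapiens) for cytotoxicity, read by CCK-8 assay, with a stated time of 5 days (a lower number here means that less compound is tolerated, a higher number that more compound is tolerated), compound 2 gives the lowest of the two numbers shown; its only neighbour, compound 1, stands apart by the one known step, a 12-fold lower number from compound 1 to compound 2 (1.08 log units; beyond the scatter). Compound 3 `NC(=O)NCCNc1cc(N2CCc3ccccc3C2)nc2ccccc12` differs from compound 2 by ureido in place of 2-aminoethyl on a saturated chain carbon, two bonds along the chain from a nitrogen on an aromatic ring. Within the data shown here, only that single step bears on this change, and it was large. Since compound 3, like compound 1, carries no chain-end amine of the kind found in compound 2, the number is expected to move back upward: a 5.4-fold higher number from compound 2 to compound 3 (0.73 log units; beyond the scatter). Compound 3 is therefore estimated at 40000 nM, with a range from 12000 nM to 120000 nM.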

Compound 3, half-maximal cytotoxic concentration: 80000 nM
Compound 3: the middle estimate sits 2.0-fold (0.30 log units) below what was measured, and the stated range covers the measured number.
By their numbers in this assay, from the lowest: compound 2; then compounds 3 and 1 (each within the scatter of the next).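

In this assay, ureido in place of 2-aminoethyl undoes the earlier drop (an 11-fold higher number from compound 2 to compound 3 (1.03 log units; beyond the scatter)), so the low number does not hold once the 4-aminobutyl chain gives way to the 2-ureidoethyl chain. Compound 3 and compound 1 stay within the scatter of each other (a 1.1-fold lower number from compound 1 to compound 3 (0.05 log units; within the scatter)), which leaves compound 2 alone on the low side among these three. Nothing measured here explains this difference.

As far as these compounds go, whether the low number of compound 2 goes with its chain-end amine or with the length of its chain remains open. A 4-hydroxybutyl chain, or a shorter chain ending in an amine, on the shared core would separate the two.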